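Replacing the acid-bearing branch in a spleen-lymphocyte series

A few compounds are considered here, and "the series" means these few. Any claim that something is new, unique, unknown or untested is made for them only; others in the source may bear on it.

Compound 1 `CCCCCCCCc1ccc(CCC(N)(CO)C(=O)O)cc1` is tested in a functional assay on the whole organism (spleen, spleen) with Rattus norvegicus as the target; a higher number here means that more compound is needed for the effect, a lower number that less compound is needed. In this assay compound 1 shows only a limit, > 10 mg/kg, so no exact number exists for it (the limit of > 10 mg/kg in this assay, at which 1 of the 2 values shown sits). Compound 2 `CCCCCCCOc1ccc(CCC(N)(CO)CCO)cc1` belongs to the same series, and in this assay compound 2 gives 0.055 mg/kg. The two values cannot be tied by a single-site comparison, since compound 2 differs from compound 1 both in the chain attached to the aromatic ring and in the branched head; what the pair shows is simply a limit on one side and a measured dose on the other.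

Compound 3 `CCCCCCCCc1ccc(CCC(N)(CCO)CCO)cc1` is not yet measured. It differs from compound 1 as follows: a group of 8 heavy atoms (5 carbon, 1 nitrogen, 2 oxygen; no ring) in place of a group of 7 heavy atoms (3 carbon, 1 nitrogen, 3 oxygen; no ring), on a saturated chain carbon, two bonds along the chain from an aromatic carbon. The head of compound 3 carries only alcohols and an amine, as the head of compound 2 does.

Compound 3 is expected to need far less compound than the limit recorded for compound 1, a step of an at least 33-fold lower number from compound 1 to compound 3 (1.52 log units; beyond the scatter) in this assay. The estimate for compound 3 is 0.3 mg/kg, with a range from 0.05 mg/kg to 3 mg/kg.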

Compound 3, dose for 50% inhibition: > 10 mg/kg
Compound 3 was reported as a limit; the forecaster's own chance of this, stated with the estimate: 10%; middle value at least 33-fold (1.52 log units) away from the limit.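

In this assay compound 3 gives > 10 mg/kg, which is a limit and not a number. Going by these compounds alone, compound 1 also stands at a limit, so no step from compound 1 to compound 3 can be read: the limit of > 10 mg/kg in this assay, at which 2 of the 3 values shown sit. The compounds shown leave open what dose either compound would actually need, and whether the exchanged group changes that dose at all.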